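The source may report more compounds than this note shows. Statements on the series, on what has been measured and on what is new or still open speak of the compounds shown alone.

Measured compounds:

Compound 1 `Cc1ccccc1Cn1cc(COc2ccc3c(=O)ccoc3c2)nn1` gives > 100000 nM in a functional assay on SGC-7901 cells (Homo sapiens) for cytotoxicity, read by MTT assay, with a stated time of 48 h (on this read-out lower numbers stand for stronger inhibition and higher numbers for weaker inhibition), which is a limit of the assay and not a number.
Compound 2 `O=c1ccoc2cc(OCc3cn(Cc4ccc([N+](=O)[O-])cc4)nn3)ccc12` gives > 100000 nM in this assay, again a limit.
Compound 3 `N#Cc1ccc(Cn2cc(COc3ccc4c(=O)ccoc4c3)nn2)cc1` gives > 100000 nM in this assay, again a limit.

Compound 1 therefore stands only at a limit, and the other two values shown are limits as well (the limit of > 100000 nM in this assay, at which 3 of the 3 values shown sit). The steps a step that the two limits leave unreadable from compound 1 to compound 2 and a step that the two limits leave unreadable from compound 1 to compound 3 both alter the group on the saturated chain carbon bound to the aromatic nitrogen, and neither can be sized because both ends sit at the limit. The step that the two limits leave unreadable from compound 2 to compound 3 is equally unreadable.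

Compound 4 `O=c1ccoc2cc(OCc3cn(Cc4ccccc4Br)nn3)ccc12` differs from compound 1 as follows: bromo in place of methyl on an aromatic carbon. The measured steps bear on it only loosely, since they swap the whole aryl group rather than one substituent on it, and none of them gives a readable size or direction. No step beyond the scatter can be expected from them; the most probable outcome is that compound 4 also returns a limit. Compound 4 is accordingly estimated at 150000 nM, within 30000 nM to 600000 nM, an expected step that the limit leaves unreadable from compound 1 to compound 4.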

Compound 4, half-maximal inhibitory concentration: > 100000 nM
Compound 4: a limit, no number (the forecaster's own chance of this, stated with the estimate: 80%); the middle value does not contradict the limit.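

No new step can be read: compound 4, like compound 1, compound 2 and compound 3, gives only a limit in this assay: the limit of > 100000 nM in this assay, at which 4 of the 4 values shown sit.
The compounds shown leave open whether any group on the saturated chain carbon bound to the aromatic nitrogen gives a readable value, and so a step of measurable size.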